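The source may hold more compounds than are shown below. What is called first, only, known or untested is meant among the compounds shown, and "the series" means these compounds.

In a functional assay on the whole organism (Tail, strain ICR) with Mus musculus as the target, in the tail flick test, with a stated time of 90 min, at a dose of 25 umol/kg by the oral route (on this read-out lower numbers stand for a weaker effect and higher numbers for a stronger effect at the one dose given), three measured compounds set the frame. Compound 1 `O=C(O)[C@@H]1CCCN1C(=O)CN(c1nc(Cl)nc2[nH]cnc12)C1CC1` gives 26%. Compound 2 `O=C(CN(c1ncnc2c1ncn2C1CCCCO1)C1CC1)N[C@@H](CO)C(=O)OCc1ccccc1` gives 32.2%, which lies within the usual scatter of the number for compound 1, so the two cannot be told apart on this read-out. Within the data shown here, compound 3 `O=C(OCc1ccccc1)[C@@H]1CCCN1C(=O)CN(c1nc(Cl)nc2[nH]cnc12)C1CC1` gives 43.3%, the only number of the three that stands beyond the scatter from compound 1. Among the measured compounds shown here, the single measured step is a number 17.3 percentage points higher from compound 1 to compound 3 (beyond the scatter), a change on the ester oxygen of the shared core of compound 1.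

Compound 4 `C[C@H](NC(=O)CN(c1nc(Cl)nc2[nH]cnc12)C1CC1)C(=O)O` differs from compound 1 in another place: (1-carboxyethyl)amino in place of 2-carboxypyrrolidin-1-yl on a carbonyl carbon. For the measured compounds named here, no measured step touches the amide side of the carbonyl in this way; the change from compound 1 to compound 3 concerns the acid becoming a benzyl ester and says nothing about exchanging the ring-bound amino acid for an open-chain one. The acid is kept in compound 4, as in compound 1, so no anchor for a move beyond the scatter exists here. Compound 4 is therefore expected to give about 25%, within roughly 10% to 40%, meaning an estimated step of a number 1 percentage points lower from compound 1 to compound 4 (within the scatter) in this assay.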

Compound 4, a percentage reported as activity, at one dose (the size of the read-out at that dose, not a potency): 43.5%
Estimate against measurement, compound 4: 18.5 percentage points below; the whole stated range lies below it.
By their numbers in this assay, from the lowest: compounds 1 and 2 (each within the scatter of the next); then compounds 3 and 4 (each within the scatter of the next).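

In this assay, the exchange of 2-carboxypyrrolidin-1-yl for (1-carboxyethyl)amino on a carbonyl carbon gives a number 17.5 percentage points higher from compound 1 to compound 4 (beyond the scatter), so the read-out responds to this place even though the carboxylic acid is kept. Among these compounds, the only earlier step beyond the scatter, a number 17.3 percentage points higher from compound 1 to compound 3 (beyond the scatter), put benzyl in place of hydrogen on an oxygen next to a carbonyl group, so the new step shows that a change leaving that hydrogen in place can also shift the number, here with a group that has no ring and fewer heavy atoms. Nothing available on these compounds accounts for the step.

The compounds shown do not separate the loss of the ring from the other differences between the two groups, and they do not show whether benzyl on the acid oxygen of compound 4 would shift its number further. From the compounds shown here alone, how a longer chain in place of the 1-carboxyethyl part, or an amine in place of its carboxylic acid, would read in this assay also remains open.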